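Swapping the Sulfonyl Aryl Group Leaves the Numbers Flat

The source may report more compounds than this note shows. Statements on the series, on what has been measured and on what is new or still open speak of the compounds shown alone.

In a functional assay on MCF7 cells (Homo sapiens) for antiproliferative activity, read by MTT assay, with a stated time of 48 h (on this read-out higher numbers stand for weaker inhibition and lower numbers for stronger inhibition), compound 1 (`Cc1ccc(S(=O)(=O)n2cc(/C=C/C(=O)c3ccncc3)c3ccccc32)cc1`) gives 48900 nM. Compound 2 (`O=C(/C=C/c1cn(S(=O)(=O)c2cccc([N+](=O)[O-])c2)c2ccccc12)c1ccncc1`) gives 36300 nM. Compound 3 (`O=C(/C=C/c1cn(S(=O)(=O)c2ccccc2[N+](=O)[O-])c2ccccc12)c1ccncc1`) gives 36900 nM, which places compound 3 within the scatter of both others. Compound 4 (`O=C(/C=C/c1cn(S(=O)(=O)c2ccc(Cl)cc2)c2ccccc12)c1ccncc1`) carries one change from compound 3: 4-chlorophenyl in place of 2-nitrophenyl on a sulfonyl sulfur. Three measured steps at that same place bear on it: a 1.3-fold lower number from compound 1 to compound 2 (0.13 log units; within the scatter), a 1.3-fold lower number from compound 1 to compound 3 (0.12 log units; within the scatter) and a 1.0-fold higher number from compound 2 to compound 3 (0.01 log units; within the scatter). Each lies within the scatter, although none of them brings in 4-chlorophenyl. No step beyond the scatter is therefore expected in this assay. The expected change is a 1.0-fold higher number from compound 3 to compound 4 (0.01 log units; within the scatter). Compound 4 is estimated at 38000 nM, with an expected range of 18000 nM to 75000 nM.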

Compound 4, half-maximal inhibitory concentration: 37500 nM
Estimate against measurement, compound 4: 1.0-fold (0.01 log units) above, and the stated range covers the measured number.
By their numbers in this assay, from the lowest: compounds 2, 3, 4 and 1 (each within the scatter of the next).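

In this assay the change shows a 1.0-fold higher number from compound 3 to compound 4 (0.01 log units; within the scatter) and a 1.0-fold higher number from compound 2 to compound 4 (0.01 log units; within the scatter) with 4-chlorophenyl on the sulfonyl sulfur, so a chlorine-bearing aryl group reads the same as either nitrophenyl. Chloro in place of methyl on an aromatic carbon gives a 1.3-fold lower number from compound 1 to compound 4 (0.12 log units; within the scatter) as well, which extends the flat picture to four aryl groups at this place. The compounds shown leave open whether a phenyl carrying an amine or a carboxylic acid, or a plain alkyl chain on the sulfur, would give a step beyond the scatter. Nothing measured here accounts for this flat picture.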